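Methyl to nitro on a well-tolerated compound

A few compounds are considered here, and "the series" means these few. Any claim that something is new, unique, unknown or untested is made for them only; others in the source may bear on it.

In an ADME assay on MT4 cells (Homo sapiens) for cytotoxicity, read by MTT assay (a higher number here means that more compound is tolerated, a lower number that less compound is tolerated), compound 1 `Cc1ccc(N(C(=O)c2cccc([N+](=O)[O-])c2)C(=S)OCCN2C(=O)c3ccccc3C2=O)cc1` gives 100000 nM and compound 2 `Cc1ccc(C(=O)N(C(=S)OCCN2C(=O)c3ccccc3C2=O)c2ccc(C)cc2)cc1` gives 83000 nM. Among the measured compounds shown here, these are the only two numbers so far, and they lie within the usual scatter of each other, so compound 2 stands level with compound 1.

Compound 3 `Cc1ccc(N(C(=O)c2ccc([N+](=O)[O-])cc2)C(=S)OCCN2C(=O)c3ccccc3C2=O)cc1` keeps the rest of compound 2 but has nitro in place of methyl on an aromatic carbon, turning 4-methylphenyl into 4-nitrophenyl: nitro in place of methyl on an aromatic carbon.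

For the measured compounds named here, one measured step bears on this change: a 1.2-fold lower number from compound 1 to compound 2 (0.08 log units; within the scatter). That step puts 4-methylphenyl in place of 3-nitrophenyl, so a ring carrying nitro has already been measured on this core. Going by that small step, no shift beyond the scatter is expected in this assay.

The step expected is a 1.1-fold higher number from compound 2 to compound 3 (0.04 log units; within the scatter). Compound 3 is estimated at 90000 nM, with an expected range of 50000 nM to 140000 nM.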

Compound 3, half-maximal cytotoxic concentration: 58000 nM
Estimate against measurement, compound 3: 1.6-fold (0.19 log units) above, and the stated range covers the measured number.
By their numbers in this assay, from the lowest: compounds 3, 2 and 1 (each within the scatter of the next).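

Putting nitro in place of methyl on this aromatic carbon gives a 1.4-fold lower number from compound 2 to compound 3 (0.16 log units; within the scatter) in this assay, so a swap from one heavy atom to three, with two hydrogen-bond acceptors entering, does not move the number beyond the scatter. Changing 3-nitrophenyl to 4-nitrophenyl gives a 1.7-fold lower number from compound 1 to compound 3 (0.24 log units; within the scatter), so the change in where the nitro sits on the ring also stays within the scatter. All three compounds therefore stand level in this assay, and nothing measured alongside them offers an explanation.

From the compounds shown here alone, it remains open whether an amine or a carboxylic acid on this same ring carbon would also stay within the scatter. A longer chain there, such as butyl, is equally untested by the compounds shown.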